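The source may report more compounds than this note shows. Statements on the series, on what has been measured and on what is new or still open speak of the compounds shown alone.

Compound 1 `Cc1ccc(Nc2nc(SCc3cn(Cc4ccccc4Cl)nn3)nc(-c3ccc(C(C)C)cc3)c2C#N)cc1`: 12200 nM. Compound 2 `COc1cc(-c2nc(SCc3cn(Cc4ccccc4Cl)nn3)nc(Nc3ccc(C)cc3)c2C#N)cc(OC)c1OC`: 20600 nM.

Both numbers come from a functional assay on MCF7 cells (Homo sapiens) for inhibition, read by MTT assay, with a stated time of 72 h; a lower number here means a stronger inhibitor, a higher number a weaker inhibitor. Compound 2 sits apart from compound 1 only by a 1.7-fold higher number from compound 1 to compound 2 (0.23 log units; within the scatter), a gap within the scatter. Compound 3 `Cc1ccc(Nc2nc(SCc3cn(Cc4ccccc4Cl)nn3)nc(-c3ccc(Cl)cc3)c2C#N)cc1` arises from compound 2 through (4-chlorophenyl in place of 3,4,5-trimethoxyphenyl on an aromatic carbon). Going by the values given here, the only measured step that bears on this change is the earlier swap of the same aryl group, a 1.7-fold higher number from compound 1 to compound 2 (0.23 log units; within the scatter), which stayed within the scatter, so no step beyond the scatter is expected in this assay. Compound 3 is therefore estimated at 13000 nM, with a range from 4500 nM to 40000 nM, an expected step of a 1.6-fold lower number from compound 2 to compound 3 (0.20 log units; within the scatter).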

Compound 3, half-maximal inhibitory concentration: 14700 nM
For compound 3 the middle estimate is 1.1-fold (0.05 log units) below the measured one, within the range that was stated.
By their numbers in this assay, from the lowest: compounds 1, 3 and 2 (each within the scatter of the next).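

Compound 3 adds a third aryl group at this position, next to the ring nitrogen, and the numbers still do not separate. Replacing 3,4,5-trimethoxyphenyl with 4-chlorophenyl, which has no hydrogen-bond acceptors, stays within the scatter (a 1.4-fold lower number from compound 2 to compound 3 (0.15 log units; within the scatter)), and so does replacing isopropyl with chloro on the phenyl ring (a 1.2-fold higher number from compound 1 to compound 3 (0.08 log units; within the scatter)). No supporting measurement explains this result. These three aryl groups therefore cannot be told apart in this assay. Still open, going by these compounds, is whether an amine or a carboxylic acid on this phenyl ring would shift the number beyond the scatter.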